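This account rests on a few compounds, and the source may have more. Where it says the series, first, only, none or still open, it means among the compounds named here.

Measured compounds and their values:
- compound 1 `COc1cc(-c2nnc(SCC(=O)c3ccc(Cl)cc3)n2N)cc(OC)c1OC`: > 100000 nM
- compound 2 `COc1cc(-c2nnc(SCC(=O)c3cccc(Br)c3)n2N)cc(OC)c1OC`: 56000 nM
- compound 3 `COc1cc(-c2nnc(SCC(=O)Nc3ccccc3)n2N)cc(OC)c1OC`: 49900 nM

All three share one core and differ only in the group on the carbonyl carbon of the side chain. In a functional assay on HepG2 cells (Homo sapiens) for antiproliferative activity, read by MTT assay, with a stated time of 48 h (on this read-out higher numbers stand for weaker inhibition and lower numbers for stronger inhibition), compound 1 gives > 100000 nM, which is a limit of the assay rather than a number (the limit of > 100000 nM in this assay, at which 1 of the 3 values shown sits). Compound 2 gives 56000 nM and compound 3 gives 49900 nM; the step of a 1.1-fold lower number from compound 2 to compound 3 (0.05 log units; within the scatter) is small.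

The unmeasured compound 4 `COc1cc(-c2nnc(SCC(=O)NCc3ccc(Cl)cc3)n2N)cc(OC)c1OC` changes compound 1 in one place: (4-chlorobenzyl)amino in place of 4-chlorophenyl on a carbonyl carbon. The closest measured step is an at least 2.0-fold lower number from compound 1 to compound 3 (0.30 log units; that floor lies within the scatter), where an amide likewise replaces the ketone; an at least 1.7-fold lower number from compound 1 to compound 2 (0.25 log units; that floor lies within the scatter) shows a comparable step. As far as these compounds go, both start from a limit, so their true size is unknown, and neither is clearly beyond the scatter. Compound 4 is therefore expected to sit near the amide compound 3, with a step of an at least 2.0-fold lower number from compound 1 to compound 4 (0.30 log units; that floor lies within the scatter) from compound 1 in this assay. The estimate for compound 4 is 50000 nM, expected to fall between 20000 nM and 150000 nM, with a real chance that only a limit is reported.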

Compound 4, half-maximal inhibitory concentration: > 100000 nM
Compound 4: only a limit was reported (the forecaster's own chance of this, stated with the estimate: 30%); middle value at least 2.0-fold (0.30 log units) away from the limit.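

In this assay compound 4 gives > 100000 nM, which is a limit of the assay and not a number. Measured against the two compounds that do have numbers, the change reads as an at least 2.0-fold higher number from compound 3 to compound 4 (0.30 log units; that floor lies within the scatter) and as an at least 1.7-fold higher number from compound 2 to compound 4 (0.25 log units; that floor lies within the scatter), so a real loss of activity is not established, while the step between compound 1 and compound 4 cannot be read, as both are limits. What is new is that an amide on this carbonyl carbon no longer goes with a measurable value: among the ketones compound 2 has a number and compound 1 does not, among the amides compound 3 has a number and compound 4 does not, so the type of link alone does not sort these compounds: the limit of > 100000 nM in this assay, at which 2 of the 4 values shown sit.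

As far as these compounds go, compound 4 differs from compound 3 in both the chlorine and the benzyl link at once, so it stays open which of the two matters, and a benzylamino or a 4-chloroanilino group at this place would separate them. From the compounds shown here alone, how weak compound 1 and compound 4 really are also stays open, as neither has a number in this range.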